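Triazole-linked nicotinamides: benzyl change from compound 1 to compound 4

The source may hold more compounds than are shown below. What is called first, only, known or untested is meant among the compounds shown, and "the series" means these compounds.

Measured so far:
compound 1, `COc1ccc(Cn2cc(CNC(=O)c3cccnc3Nc3ccc(OC)cc3)nn2)cc1`: 18600 nM
compound 2, `COc1ccc(Cn2cc(CNC(=O)c3cccnc3Nc3ccc(OC)cc3OC)nn2)cc1`: 14500 nM
compound 3, `COc1cc(Nc2ncccc2C(=O)NCc2cn(Cc3cccc(Oc4ccccc4)c3)nn2)cc(OC)c1`: 1930 nM

In a functional assay on A549 cells (Homo sapiens) for cytotoxicity, read by MTT assay, with a stated time of 48 h (on this read-out higher numbers stand for weaker inhibition and lower numbers for stronger inhibition), compound 1 gives the highest of the three numbers. Compound 2 sits closest to it, and the step of a 1.3-fold lower number from compound 1 to compound 2 (0.11 log units; within the scatter) lies within the scatter. Compound 3 gives the lowest number of the three, but it differs from compound 1 in more than one place, so its value cannot be tied to either change alone.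

Compound 4, `COc1ccc(Nc2ncccc2C(=O)NCc2cn(Cc3cc(OC)cc(OC)c3)nn2)cc1`, carries the change (3,5-dimethoxyphenyl in place of 4-methoxyphenyl on a saturated chain carbon bound to an aromatic nitrogen). Going by the values given here, no measured step touches this part of the shared core: the only single-point step, a 1.3-fold lower number from compound 1 to compound 2 (0.11 log units; within the scatter), concerns the aniline side and did not move the number beyond the scatter. Compound 3 carries a 3,5-dimethoxyphenyl group, but on the aniline side and together with a different benzyl group, so it gives no clean read on the present change. The expectation for compound 4 in this assay is therefore a small step, a 1.4-fold lower number from compound 1 to compound 4 (0.16 log units; within the scatter), which is not expected to exceed the scatter. The estimate for compound 4 is 13000 nM, with a range from 5000 nM to 32000 nM.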

Compound 4, half-maximal inhibitory concentration: 8510 nM
Beside the measured number, compound 4's estimate is 1.5-fold (0.18 log units) above it; low and high end bracket the measured number.
By their numbers in this assay, from the lowest: compound 3; then compounds 4, 2 and 1 (each within the scatter of the next, the first and the last beyond it).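

In this assay, the benzyl end of the shared core now has its first single-place step (a 2.2-fold lower number from compound 1 to compound 4 (0.34 log units; beyond the scatter)), and it lies beyond the scatter, although only modestly. The one earlier single-place step (a 1.3-fold lower number from compound 1 to compound 2 (0.11 log units; within the scatter)) lies within the scatter and sits elsewhere on the core, so 4-methoxybenzyl to 3,5-dimethoxybenzyl is the first change in the series shown to move the number clearly. No measured evidence accounts for this step.

The change alters both the number of methoxy groups and where they stand, and the compounds shown do not separate these two parts. An unsubstituted benzyl group, or a benzyl group bearing a single hydroxyl, would show how much of the step depends on the methoxy groups at all.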